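Taking the methyl away from compound 3

This account rests on a few compounds, and the source may have more. Where it says the series, first, only, none or still open, it means among the compounds named here.

Measured in a functional assay on a cell-free system (plasma, Homo sapiens) for inhibition, with Plasma (Rattus norvegicus) as the target; a higher number here means a weaker inhibitor, a lower number a stronger inhibitor:
compound 1 `O=c1cc(N2CCNCC2)c2ccccc2o1`: 250000 nM
compound 2 `O=c1cc(N2CCNCC2)c2ccc(OCc3ccccc3)cc2o1`: 78800 nM
compound 3 `Cc1c(OCc2cccnc2)ccc2c(N3CCNCC3)cc(=O)oc12`: 1420 nM

Of the three, compound 3 has the lowest number, at 1420 nM. Compound 4 `O=c1cc(N2CCNCC2)c2ccc(OCc3cccnc3)cc2o1` differs from it by a single change, hydrogen in place of methyl on an aromatic carbon. Among the compounds with values here, no measured step isolates this change. The only one available, a 3.2-fold lower number from compound 1 to compound 2 (0.50 log units; beyond the scatter), is a modest step for benzyloxy in place of hydrogen, so it bears only loosely. Compound 2 also lacks the methyl and gives 78800 nM, so a moderate move to a higher number is expected. In this assay the expected step is a 4.9-fold higher number from compound 3 to compound 4 (0.69 log units; beyond the scatter). The estimated value for compound 4 is 7000 nM, with an expected range from 2000 nM to 30000 nM.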

Compound 4, half-maximal inhibitory concentration: 18900 nM
Estimate against measurement, compound 4: 2.7-fold (0.43 log units) below; low and high end bracket the measured number.
By their numbers in this assay, from the lowest: compound 3; then compound 4; then compound 2; then compound 1.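

In this assay, taking away the methyl ortho to the (pyridin-3-yl)methoxy group gives a 13-fold higher number from compound 3 to compound 4 (1.12 log units; beyond the scatter) as a large step, the same size as a 13-fold lower number from compound 1 to compound 4 (1.12 log units; beyond the scatter) when that whole group enters the core. Pyridin-3-yl in place of phenyl gives only a 4.2-fold lower number from compound 2 to compound 4 (0.62 log units; beyond the scatter) as a modest step, so this single methyl position counts for more here than that ring change. Nothing measured here explains the size of the methyl step. On these data alone, whether ethyl, chlorine or methoxy on this carbon would keep the lower number stays open. Also open, as far as these compounds go, is whether methyl gives a similar step alongside benzyloxy.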